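This account rests on a few compounds, and the source may have more. Where it says the series, first, only, none or still open, it means among the compounds named here.

In an assay on isolated protein for inhibition of vascular endothelial growth factor receptor 1 (Homo sapiens), read by ELISA, with a stated time of 20 min, tested at 1 uM (a lower number here means less inhibition, a higher number more inhibition at the concentration tested (going by the name of the read-out)), compound 2 `COc1cc2ncnc(Nc3cccc(B(O)O)c3)c2cc1OC` is reported as "not active" (no number reported), so there is no single number for it, and compound 1 `COCCOc1cc2ncnc(Nc3cccc(B(O)O)c3)c2cc1OCCOC` is likewise reported in this assay as "not active" (no number reported). Only compound 3 `COc1cc2ncnc(Nc3cccc(C(=O)O)c3)c2cc1OC` returns a figure, giving 32% in this assay. Compound 4 `COCCOc1cc2ncnc(Nc3cccc(B(O)O)c3)c2cc1OC` has not yet been tested; it differs from compound 2 by methoxymethyl in place of hydrogen on a saturated chain carbon bound to an oxygen on an aromatic ring, a change on a saturated chain carbon bound to an oxygen on an aromatic ring. With compound 2 at the bottom of the readable range, no step beyond the usual scatter of this assay is expected in either direction, and compound 1 points the same way. Compound 4 is therefore estimated to give 8% in this assay, within 0% to 25%.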

Compound 4, a percentage reported as inhibition, at one concentration (the size of the read-out at that concentration, not a potency): 19%
Estimate against measurement, compound 4: 11 percentage points below; the measured number falls inside the stated range.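

Among these compounds, compound 2 carries no single number, and no step from it to compound 4 can be read. The compounds shown leave open how large any effect of methoxymethyl in place of hydrogen is. No available evidence bears on this result.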